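Chain length at the amide nitrile in a thioether series

This account rests on a few compounds, and the source may have more. Where it says the series, first, only, none or still open, it means among the compounds named here.

Compound 1 `Cc1ccc(Sc2cnc(Nc3ccccn3)s2)cc1C(=O)NCC#N` and compound 2 `Cc1ccc(Sc2cnc(Nc3ccccn3)s2)cc1C(=O)NCCC#N` share one core and differ only in the chain ending in the nitrile. In an assay on isolated protein for inhibition of high affinity nerve growth factor receptor (Homo sapiens) (a higher number here means a weaker inhibitor, a lower number a stronger inhibitor), compound 1 gives 44 nM, and compound 2 gives 65 nM. The change between them is cyanomethyl in place of cyano on a saturated chain carbon bound to an amide-type nitrogen, and the step it made, a 1.5-fold higher number from compound 1 to compound 2 (0.17 log units; within the scatter), is within the scatter, so the two numbers cannot be ordered.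

Compound 3 `Cc1ccc(Sc2cnc(Nc3cccc(Br)n3)s2)cc1C(=O)N(C)CC#N` is built on a different core; how that core differs from the core of compound 1 is not broken down here. In this assay, within the data shown here, compound 3 gives 2 nM, the lowest of the three numbers so far, with compound 1 and compound 2 both beyond the scatter above it.

Compound 4 `Cc1ccc(Sc2cnc(Nc3cccc(Br)n3)s2)cc1C(=O)N(C)CCC#N` carries the same change relative to compound 3 that compound 2 carries relative to compound 1, namely (cyanomethyl in place of cyano on a saturated chain carbon bound to an amide-type nitrogen). It is not yet measured in this assay. Among the measured compounds shown here, the only measured instance of this change is the pair compound 1 to compound 2, where the step was a 1.5-fold higher number from compound 1 to compound 2 (0.17 log units; within the scatter), and nothing indicates that the chain extension matters more on the core of compound 3 than on the core of compound 1. The expected step from compound 3 to compound 4 is therefore a small one, a 1.5-fold higher number from compound 3 to compound 4 (0.18 log units; within the scatter), resting on that single measured pair. Because compound 3 gives 2 nM, compound 4 is estimated at 3 nM, with a likely range from 1.2 nM to 8 nM.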

Compound 4, half-maximal inhibitory concentration: 10 nM
Beside the measured number, compound 4's estimate is 3.3-fold (0.52 log units) below it, and the stated range ends below it.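

In this assay, lengthening the chain from cyanomethyl to 2-cyanoethyl on the core of compound 3 gives a 5.0-fold higher number from compound 3 to compound 4 (0.70 log units; beyond the scatter), a step that can be read, whereas the same change on the core of compound 1 stays within the scatter. Among these compounds, the change therefore does not carry over from one core to the other with the same size: the same change on two cores in this assay, a 1.5-fold higher number (0.17 log units; within the scatter) from compound 1 to compound 2 and a 5.0-fold higher number (0.70 log units; beyond the scatter) from compound 3 to compound 4, 3.4-fold (0.53 log units) apart, beyond the scatter of two such steps This rests on only two matched pairs, and the difference between the two cores is not broken down, so the data neither tie the larger step to any one part of the core of compound 3 nor show how the change would behave on a third core.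

The compounds shown stop at the 2-cyanoethyl chain, leaving open whether a longer chain such as 3-cyanopropyl would raise the number further on the core of compound 3 or leave it unchanged. Also open, on these data alone, is how far the nitrile itself matters on either core, which a chain ending in a carboxylic acid or an amine in its place would begin to address.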